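Chain on the aromatic nitrogen: compound 2 to compound 3

A few compounds are considered here, and "the series" means these few. Any claim that something is new, unique, unknown or untested is made for them only; others in the source may bear on it.

Two compounds of this series have numbers in an assay on isolated protein (Oryctolagus cuniculus) with Thromboxane-A synthase (Homo sapiens) as the target, tested at 1 uM; on this read-out higher numbers stand for more inhibition at the one concentration tested (going by the name of the read-out) and lower numbers for less inhibition. Compound 1 `CCCCn1nc(-c2cccnc2)c2ccccc2c1=O` gives 91%, and compound 2 `C=CCn1nc(-c2cccnc2)c2ccccc2c1=O` gives 70%. For the measured compounds named here, the one step so far, a number 21 percentage points lower from compound 1 to compound 2 (beyond the scatter), leaves compound 2 as the lowest of the two numbers, with compound 1 as its only neighbour and beyond the scatter above it.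

Compound 3 `CC(C)=CCn1nc(-c2cccnc2)c2ccccc2c1=O` is not yet measured. Its change from compound 2 is 2-methylprop-1-en-1-yl in place of vinyl on a saturated chain carbon bound to an aromatic nitrogen. The same place was changed in the measured step, which took the chain from propyl to vinyl and cost a modest amount; compound 3 lengthens the chain again, now with a branched unsaturated group. Going by the values given here, the only bearing evidence is therefore that a shorter chain on this carbon gave the lower number.

Compound 3 is expected to sit above compound 2 in this assay, with an estimated step of a number 15 percentage points higher from compound 2 to compound 3 (beyond the scatter). The estimate for compound 3 is 85%, with a range of 65% to 97%.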

Compound 3, a percentage reported as inhibition, at one concentration (the size of the read-out at that concentration, not a potency): 94%
Beside the measured number, compound 3's estimate is 9 percentage points below it; the measured number falls inside the stated range.
By their numbers in this assay, from the lowest: compound 2; then compounds 1 and 3 (each within the scatter of the next).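

In this assay the change from vinyl to 2-methylprop-1-en-1-yl gives a number 24 percentage points higher from compound 2 to compound 3 (beyond the scatter) and so shows that a double bond outside aromatic rings on this saturated chain carbon bound to an aromatic nitrogen does not by itself go with the lower number, which among these three compounds is seen only with vinyl. Comparing the saturated and branched unsaturated chains gives a number 3 percentage points higher from compound 1 to compound 3 (within the scatter) and leaves compound 1 and compound 3 level at this one concentration, so propyl and 2-methylprop-1-en-1-yl cannot be told apart on this read-out. No measurement at hand explains either step.

The compounds shown leave open how the number responds at this place to a longer saturated chain, a benzyl group, or a chain ending in an amine or a carboxylic acid. They also leave open whether both methyl groups of 2-methylprop-1-en-1-yl are needed, which a chain with a single methyl group on the double bond would test, and a single-concentration percentage cannot separate compound 1 from compound 3 in potency.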